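This account rests on a few compounds, and the source may have more. Where it says the series, first, only, none or still open, it means among the compounds named here.

Values in a functional assay on MCF7 cells (Homo sapiens) for antiproliferative activity, read by sulforhodamine B assay, with a stated time of 48 h (a higher number here means a weaker inhibitor, a lower number a stronger inhibitor), so far
- compound 1 (`Cc1ccc(NS(=O)(=O)c2ccc(N3CCNC3=O)cc2)cc1`) gives 610 nM
- compound 2 (`CC(C)(C)c1ccc(NS(=O)(=O)c2ccc(N3CCNC3=O)cc2)cc1`) gives > 1000 nM as a limit

Compound 2 is reported only as a limit, > 1000 nM with no number. Compound 3 (`CCCCOc1ccc(NS(=O)(=O)c2ccc(N3CCNC3=O)cc2)cc1`) carries butoxy in place of tert-butyl on an aromatic carbon. Among the measured compounds shown here, the sole measured step bearing on this change is an at least 1.6-fold higher number from compound 1 to compound 2 (0.21 log units; that floor lies within the scatter) and it gives only a floor. For the measured compounds named here, with compound 1 at 610 nM as the one number available, no step beyond the scatter is expected in this assay. The estimated step (an at least 1.2-fold lower number from compound 2 to compound 3 (0.09 log units; that floor lies within the scatter)) reflects that expectation. For compound 3 the estimated value is 800 nM (expected range 250 nM to 2500 nM).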

Compound 3, half-maximal inhibitory concentration: 870 nM
Estimate against measurement, compound 3: 1.1-fold (0.04 log units) below; the range from low to high includes it.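

In this assay, butoxy on this aromatic carbon gives a readable number, where tert-butyl gave only a limit. Against methyl, the change is a 1.4-fold higher number from compound 1 to compound 3 (0.15 log units; within the scatter) and so does not separate the two groups at this position. Against tert-butyl, the reading is an at least 1.1-fold lower number from compound 2 to compound 3 (0.06 log units; that floor lies within the scatter) and remains only a floor, since compound 2 is reported as a limit: the limit of > 1000 nM in this assay, at which 1 of the 3 values shown sits.

From the compounds shown here alone, whether any group at this position moves the number beyond the scatter remains open. An amine or a carboxylic acid here would test that, as would a longer chain than butoxy.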